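The source may hold more compounds than are shown below. What is called first, only, known or untested is meant among the compounds shown, and "the series" means these compounds.

Measured in a functional assay on LoVo cells (Homo sapiens) for inhibition, read by MTT assay, with a stated time of 24 h; on this read-out higher numbers stand for weaker inhibition and lower numbers for stronger inhibition:
- compound 1 `CC1(C)[C@H]2CC[C@]1(C)N(Cc1cn(-c3ccc(F)cc3)nn1)C(=O)C2`: 40 nM
- compound 2 `COc1ccccc1-n1cc(CN2C(=O)C[C@@H]3CC[C@@]2(C)C3(C)C)nn1`: 70 nM
- compound 3 `CC1(C)[C@H]2CC[C@]1(C)N(Cc1cn(-c3ccccc3)nn1)C(=O)C2`: 50 nM

Compound 3 lies within the scatter of both other compounds, as the steps show: a 1.3-fold higher number from compound 1 to compound 3 (0.10 log units; within the scatter) and a 1.4-fold lower number from compound 2 to compound 3 (0.15 log units; within the scatter). The remaining step, a 1.8-fold higher number from compound 1 to compound 2 (0.24 log units; within the scatter), is also within the scatter.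

Compound 4 `CC1(C)[C@H]2CC[C@]1(C)N(Cc1cn(-c3ccc(Cl)cc3)nn1)C(=O)C2` has not yet been measured. It keeps the shared core of compound 3 but carries chloro in place of hydrogen on an aromatic carbon, para to a large group, so that phenyl becomes 4-chlorophenyl: chloro in place of hydrogen on an aromatic carbon. Among the measured compounds shown here, no measured compound carries chloro. The nearest evidence is the pair with 4-fluorophenyl and phenyl, a 1.3-fold higher number from compound 1 to compound 3 (0.10 log units; within the scatter), which stays within the scatter. The methoxy step, a 1.4-fold lower number from compound 2 to compound 3 (0.15 log units; within the scatter), bears on the change less directly and is also within the scatter.

No change beyond the scatter is therefore expected in this assay, and the estimated step is a 1.1-fold lower number from compound 3 to compound 4 (0.05 log units; within the scatter). Compound 4 is expected to give 45 nM, with an estimated range from 25 nM to 85 nM.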

Compound 4, half-maximal inhibitory concentration: 160 nM
Estimate against measurement, compound 4: 3.6-fold (0.55 log units) below; the whole stated range lies below it.
By their numbers in this assay, from the lowest: compounds 1, 3 and 2 (each within the scatter of the next); then compound 4.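

In this assay, the aromatic carbon para to a large group proves sensitive to which halogen it carries: a 4.0-fold higher number from compound 1 to compound 4 (0.60 log units; beyond the scatter) lies beyond the scatter, whereas fluoro and hydrogen could not be told apart there. Chloro in place of hydrogen gives a 3.2-fold higher number from compound 3 to compound 4 (0.51 log units; beyond the scatter) and is the first change at this place to exceed the scatter. Exchanging 2-methoxyphenyl for 4-chlorophenyl gives a 2.3-fold higher number from compound 2 to compound 4 (0.36 log units; beyond the scatter) as well, so compound 4 is the weakest of the four, while the other three remain within the scatter of one another.

Nothing among the data shown gives a reason for this step. Going by these compounds, whether bromo, methyl or trifluoromethyl at this place would fall with chloro or with fluoro remains open.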